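A few compounds are considered here, and "the series" means these few. Any claim that something is new, unique, unknown or untested is made for them only; others in the source may bear on it.

Measured compounds:
- compound 1, `C/C(=C\C(=O)Nc1ccccc1OCCCC(=O)O)c1ccc2c(ccn2C)c1`: 780 nM
- compound 2, `CCCCC(C)n1ccc2cc(/C(C)=C/C(=O)Nc3ccccc3OCCCC(=O)O)ccc21`: 6 nM
- compound 3, `CCCCC(CC)n1ccc2cc(/C(C)=C/C(=O)Nc3ccccc3OCCCC(=O)O)ccc21`: 7.1 nM

These three share one core and differ only in the group on the aromatic nitrogen. In an assay on Prostate gland for inhibition of steroid 5-alpha-reductase (Rattus norvegicus) (a higher number here means a weaker inhibitor, a lower number a stronger inhibitor), compound 1 gives 780 nM, the highest of the three numbers. Compound 2 gives 6 nM and compound 3 gives 7.1 nM, so compound 3 stands second highest of the three; its nearest neighbour is compound 2, a 1.2-fold higher number from compound 2 to compound 3 (0.07 log units; within the scatter), and its furthest is compound 1, a 110-fold lower number from compound 1 to compound 3 (2.04 log units; beyond the scatter).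

Compound 4, `CCCCc1ccc(Cn2ccc3cc(/C(C)=C/C(=O)Nc4ccccc4OCCCC(=O)O)ccc32)cc1`, has not yet been measured in this assay. Relative to compound 3 its change is 4-butylbenzyl in place of 1-ethylpentyl on an aromatic nitrogen.

Going by the values given here, two measured steps bear on this: a 130-fold lower number from compound 1 to compound 2 (2.11 log units; beyond the scatter) and a 110-fold lower number from compound 1 to compound 3 (2.04 log units; beyond the scatter). Both show that replacing methyl on the aromatic nitrogen by a branched alkyl chain brings a large drop in the number, while a 1.2-fold higher number from compound 2 to compound 3 (0.07 log units; within the scatter) shows that the two branched chains are indistinguishable within the scatter. Among the compounds with values here, no measured step goes from a branched alkyl to 4-butylbenzyl, so the size of this particular step is not known from the data. Given that both large groups on this nitrogen gave the same low numbers, compound 4 is expected to stay close, with the step of a 1.1-fold higher number from compound 3 to compound 4 (0.05 log units; within the scatter) expected to lie within the scatter. The estimated value for compound 4 is 8 nM, in the range 3 nM to 25 nM.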

Compound 4, half-maximal inhibitory concentration: 100 nM
The estimate for compound 4 lay 13-fold (1.10 log units) below the measured number; the whole stated range lies below it.
By their numbers in this assay, from the lowest: compounds 2 and 3 (each within the scatter of the next); then compound 4; then compound 1.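

In this assay, the group on the aromatic nitrogen proves not to be a place where any large group will do: 4-butylbenzyl in place of 1-ethylpentyl gives a clear loss (a 14-fold higher number from compound 3 to compound 4 (1.15 log units; beyond the scatter)), and 4-butylbenzyl in place of 1-methylpentyl gives one of similar size (a 17-fold higher number from compound 2 to compound 4 (1.22 log units; beyond the scatter)), whereas the two branched chains could not be told apart from each other. Heavy-atom count alone therefore does not set the number here, since the entering group, with 11 heavy atoms and one six-membered aromatic ring, does worse than the 7-carbon 1-ethylpentyl, yet it still keeps part of the gain over the small methyl group of the first compound (a 7.8-fold lower number from compound 1 to compound 4 (0.89 log units; beyond the scatter)). Nothing available gives a measured reason for this loss.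

The compounds shown leave open whether the loss belongs to the benzyl ring itself or to the butyl tail on it, which a plain benzyl group, a cyclohexylmethyl group or a straight hexyl chain on the same nitrogen would help to separate. They also leave open whether the same order of groups would hold with a shorter acid chain on the shared core.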